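One Halophenyl Swap, Tried on a Second Core

A few compounds are considered here, and "the series" means these few. Any claim that something is new, unique, unknown or untested is made for them only; others in the source may bear on it.

Compound 1 `COc1ccc2nc(N(Cc3cc(-c4ccc(Br)cc4)no3)c3nc4ccc(F)cc4s3)sc2c1` and compound 2 `COc1ccc2nc(N(Cc3cc(-c4ccccc4F)no3)c3nc4ccc(F)cc4s3)sc2c1` share one core and differ in a single place, (2-fluorophenyl in place of 4-bromophenyl on an aromatic carbon). In a functional assay on A549 cells (Homo sapiens) for antiproliferative activity, read by MTT assay (a higher number here means a weaker inhibitor, a lower number a stronger inhibitor), compound 1 gives 32700 nM, and compound 2 gives 51800 nM. Compound 3 `Brc1ccc(-c2cc(CN(c3ncccn3)c3nc4ccccc4s3)on2)cc1` is built on a different core; the difference between the two cores is not broken down here. In this assay compound 3 gives 31500 nM, a number that sits within the scatter of both compound 1 and compound 2. Compound 4 `Fc1ccccc1-c1cc(CN(c2ncccn2)c2nc3ccccc3s2)on1` has not yet been measured. It differs from compound 3 by 2-fluorophenyl in place of 4-bromophenyl on an aromatic carbon, the same change that separates compound 1 from compound 2, made at the same place on the ring. Because the measured step was a 1.6-fold higher number from compound 1 to compound 2 (0.20 log units; within the scatter), a step of similar size is expected here, namely a 1.6-fold higher number from compound 3 to compound 4 (0.20 log units; within the scatter). That expectation rests on one pair alone, and a single pair cannot show whether the change carries over unchanged onto a second core. Compound 4 is therefore expected to give about 50000 nM in this assay, most likely between 25000 nM and 100000 nM.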

Compound 4, half-maximal inhibitory concentration: 25400 nM
The estimate for compound 4 lay 2.0-fold (0.29 log units) above the measured number; measured number inside the range.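

On the second core, the swap of 4-bromophenyl for 2-fluorophenyl gives a 1.2-fold lower number from compound 3 to compound 4 (0.09 log units; within the scatter) in this assay. Set side by side, the two steps do not differ by more than repeated measurement would allow: the same change on two cores in this assay, a 1.6-fold higher number (0.20 log units; within the scatter) from compound 1 to compound 2 and a 1.2-fold lower number (0.09 log units; within the scatter) from compound 3 to compound 4, 2.0-fold (0.29 log units) apart, within the scatter of two such steps. This fits the change carrying over between these two cores, but neither step stands clear of the scatter, so the two pairs cannot show that the change has any real effect to carry, and they say nothing about cores beyond these two.

As far as these compounds go, all four compounds carry a halophenyl group at this place on the five-membered aromatic ring, so it remains open whether an amine, a carboxylic acid or a longer chain there would move the number on either core. From the compounds shown here alone, it also remains open which parts of the two cores matter in this assay, since they differ in more than one place.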